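Estimating a thiophene amide from one cytotoxicity value

A few compounds are considered here, and "the series" means these few. Any claim that something is new, unique, unknown or untested is made for them only; others in the source may bear on it.

Measured in a functional assay on MCF7 cells (Homo sapiens) for cytotoxicity, read by MTT assay, with a stated time of 72 h; a lower number here means a stronger inhibitor, a higher number a weaker inhibitor:
Compound 1 `CS(=O)(=O)Oc1c(C(=O)NCc2ccc(F)cc2)nc(Br)c2cccnc12`: "not determined" (no result reported)
Compound 2 `Nc1cccc(Nc2c(C(=O)NCc3ccc(F)cc3)nc(Br)c3cccnc23)c1`: 8000 nM
Compound 3 `N[C@H]1CC[C@H](Nc2c(C(=O)NCc3ccc(Cl)cc3Cl)nc(Br)c3cccnc23)CC1`: "not determined" (no result reported)

The numbers leave compound 3 without a place in any ranking. Its entry in this assay reads "not determined" (no result reported), so it cannot be placed above or below anything else. Compound 1 has no single number either. Within the data shown here, that leaves compound 2, at 8000 nM, as the only real measurement in this small set.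

The next structure is compound 4 `N[C@H]1CC[C@H](Nc2c(C(=O)NCc3cccs3)nc(Br)c3cccnc23)CC1`. The change is thiophen-2-yl in place of 2,4-dichlorophenyl on a saturated chain carbon bound to an amide-type nitrogen. Put simply, thiophen-2-yl takes the place of 2,4-dichlorophenyl on a saturated chain carbon bound to an amide-type nitrogen, and the rest of the molecule stays the same.

Among the measured compounds shown here, no pair of measured compounds differs in just one place, so the data offer no step to borrow. The expectation in this assay is therefore a step from compound 3 to compound 4 no larger than the usual scatter of repeated measurements, with neither direction favoured. This cannot be checked directly, since compound 3 has no number. For the measured compounds named here, the only anchor is compound 2 at 8000 nM, so the estimate stays broad. For compound 4 the expected value is 6000 nM, with an estimated range from 1500 nM to 25000 nM.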

Compound 4, half-maximal inhibitory concentration: 7300 nM
Compound 4: middle estimate off by 1.2-fold (0.09 log units), on the low side; the range from low to high includes it.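

Among these compounds, compound 3 reads "not determined" (no result reported) in this assay while compound 4 gives 7300 nM so no step between these two compounds can be read. The compounds shown leave open whether thiophen-2-yl in place of 2,4-dichlorophenyl shifts the value in this assay at all. No measured evidence bears on this result.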